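A Smaller Lactone Terminus and Its Expected Cytotoxicity

The source may report more compounds than this note shows. Statements on the series, on what has been measured and on what is new or still open speak of the compounds shown alone.

Measured so far:
compound 1, `C=C1[C@@H](O)C[C@H]2C(C)(C)CCC[C@]2(C)[C@H]1/C=C/C1=CC(=O)OC1O`, 7.29 ug/mL
compound 2, `C=C1C[C@@H](O)[C@H]2C(C)(C)CCC[C@]2(C)[C@H]1/C=C/c1ccoc1`, 6.21 ug/mL
compound 3, `C=C1C[C@@H](O)[C@H]2C(C)(C)CCC[C@]2(C)[C@H]1C/C=C1/CC(OC)OC1=O`, 8.74 ug/mL

All three were tested in a functional assay on SGC-7901 cells (Homo sapiens) for cytotoxicity, read by sulforhodamine B assay, with a stated time of 48 h; on this read-out lower numbers stand for stronger inhibition and higher numbers for weaker inhibition. Compound 1 gives 7.29 ug/mL, a number that lies between those of compound 2 and compound 3; yet every pair among the three falls within the usual scatter of repeated measurements, so none of them can be set apart from the others on this read-out.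

Compound 4, `C=C1[C@@H](O)C[C@H]2C(C)(C)CCC[C@]2(C)[C@H]1/C=C/C1=CCOC1=O`, has not yet been measured. It differs from compound 1 in one place: a group of 6 heavy atoms (4 carbon, 2 oxygen; one five-membered non-aromatic ring with 1 hetero atom) in place of a group of 7 heavy atoms (4 carbon, 3 oxygen; one five-membered non-aromatic ring with 1 hetero atom), on a double-bonded chain carbon bound to a double-bonded chain carbon. The group that enters carries no hydrogen-bond donor, where the group that leaves carried one.

Among the compounds with values here, no pair of measured compounds differs in a single place, so there is no measured step to lean on. What the three measured compounds do show is that rather different side-chain termini on the shared core all give numbers within the scatter of one another. On that ground compound 4 is expected to show a step from compound 1 of about a 1.0-fold lower number from compound 1 to compound 4 (0.02 log units; within the scatter) in this assay, which is no change beyond the scatter. Compound 4 is therefore estimated at 7 ug/mL, with a range from 3.5 ug/mL to 14 ug/mL.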

Compound 4, half-maximal inhibitory concentration: 14.5 ug/mL
Beside the measured number, compound 4's estimate is 2.1-fold (0.32 log units) below it; measured number outside the range, above it.
By their numbers in this assay, from the lowest: compounds 2, 1, 3 and 4 (each within the scatter of the next, the first and the last beyond it).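

In this assay, the set now holds its first step between compounds that differ in one place: a 2.0-fold higher number from compound 1 to compound 4 (0.30 log units; within the scatter). The step shows that, on a double-bonded chain carbon bound to a double-bonded chain carbon, a group of 6 heavy atoms with 0 hydrogen-bond donors and 2 hydrogen-bond acceptors can stand in place of a group of 7 heavy atoms with 1 hydrogen-bond donor and 3 hydrogen-bond acceptors without a change beyond the scatter on this read-out, so the donor in the leaving group is not shown to be needed at this position. No measurement shown here gives a reason for the size of this step.

The compounds shown leave open whether this position would accept a terminus of a different kind, such as a carboxylic acid, an amine or a longer chain, without a change beyond the scatter. They also leave open whether the donor and the additional oxygen matter separately, since both differ in this one step and no compound shown separates them.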